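The source may hold more compounds than are shown below. What is called first, only, known or untested is meant among the compounds shown, and "the series" means these compounds.

In a functional assay on A549 cells (Homo sapiens) for inhibition, read by sulforhodamine B assay, with a stated time of 72 h (a lower number here means a stronger inhibitor, a higher number a weaker inhibitor), two amides built on the same core have been measured. Compound 1 `Nc1sc(-c2ccc(Cl)cc2)c(-c2ccc(Cl)cc2)c1C(=O)NC1CCCCC1` gives 2410 nM, and compound 2 `Nc1sc(-c2ccc(Cl)cc2)c(-c2ccc(Cl)cc2)c1C(=O)N1CCOCC1` gives 1870 nM. The step between them is a 1.3-fold lower number from compound 1 to compound 2 (0.11 log units; within the scatter), so compound 2 stands level with compound 1. Compound 3 `COc1ccc(CNC(=O)c2c(N)sc(-c3ccc(Cl)cc3)c2-c2ccc(Cl)cc2)cc1` has (4-methoxybenzyl)amino in place of morpholin-4-yl on a carbonyl carbon. Going by the values given here, the only measured step that bears on this change is a 1.3-fold lower number from compound 1 to compound 2 (0.11 log units; within the scatter), which exchanged a group at the same carbonyl carbon and stayed small. Among the compounds with values here, no measured compound carries the entering group, so this single step is thin support and the range is kept wide. Nothing beyond the scatter is expected in this assay, and no direction is favoured: the expected change is a 1.1-fold higher number from compound 2 to compound 3 (0.03 log units; within the scatter). For compound 3 the estimated value is 2000 nM, with an expected range of 900 nM to 4500 nM.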

Compound 3, half-maximal inhibitory concentration: 18200 nM
Estimate against measurement, compound 3: 9.1-fold (0.96 log units) below; measured number outside the range, above it.
By their numbers in this assay, from the lowest: compounds 2 and 1 (each within the scatter of the next); then compound 3.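

In this assay the group on this carbonyl carbon turns out to matter: the earlier exchange stayed within the scatter, but (4-methoxybenzyl)amino in place of morpholin-4-yl gives a 9.7-fold higher number from compound 2 to compound 3 (0.99 log units; beyond the scatter). With 4-methoxybenzyl in place of cyclohexyl on the amide-type nitrogen, the reading is a 7.6-fold higher number from compound 1 to compound 3 (0.88 log units; beyond the scatter), so the weakening appears against both earlier amides, including the one that also carries the amide hydrogen. No measurement offered here accounts for this weakening.

What the compounds shown leave open is whether the step belongs to the aromatic ring or to its methoxy group, a question an unsubstituted benzyl amide would address. Also open, as far as these compounds go, is whether a piperidine or a piperazine at the same carbonyl carbon would stay level with morpholin-4-yl.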